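This account rests on a few compounds, and the source may have more. Where it says the series, first, only, none or still open, it means among the compounds named here.

Measured so far:
compound 1, `CS(=O)(=O)c1ccc(C(=O)NCC(=O)N(Cc2ccccc2)Cc2ccccc2)cc1[N+](=O)[O-]`: 11900 nM
compound 2, `CCCN(C(=O)CN(C)C(=O)c1ccc(S(C)(=O)=O)c([N+](=O)[O-])c1)c1ccccc1`: > 27000 nM

In an ADME assay on HepG2 cells (Homo sapiens) for cytotoxicity, read by CellTiter-Glo and ATP content, with a stated time of 72 h (on this read-out lower numbers stand for an effect already at smaller amounts and higher numbers for an effect only at larger amounts of compound), compound 1 gives 11900 nM. For compound 2 the read-out is a limit of the assay and not a number, > 27000 nM, as noted in the limit of > 27000 nM in this assay, at which 1 of the 2 values shown sits; compound 2 therefore stands at the limit, with no measured number of its own. Among the measured compounds shown here, no step between two measured compounds is available, so the two values shown say only that compound 1 sits at a number while compound 2 sits at a limit.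

Compound 3, `CN(CC(=O)N1CCc2ccccc2C1)C(=O)c1ccc(S(C)(=O)=O)c([N+](=O)[O-])c1`, differs from compound 2 by 1,2,3,4-tetrahydroisoquinolin-2-yl in place of phenyl(propyl)amino on a carbonyl carbon. Given that compound 2 rests at a limit, the step from compound 2 to compound 3 is expected to be small, with no clear direction beyond the scatter, as estimated in an at least 1.0-fold lower number from compound 2 to compound 3 (0.03 log units; that floor lies within the scatter). Compound 3 is expected to give about 25000 nM in this assay, within a range from 9000 nM to 60000 nM, with a real chance that only a limit is again reported.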

Compound 3, half-maximal effective concentration: > 27000 nM
Compound 3: a limit, no number (the forecaster's own chance of this, stated with the estimate: 50%); middle value at least 1.0-fold (0.03 log units) from the limit.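

In this assay compound 3 gives > 27000 nM, a limit of the assay and not a number. Compound 2 also sits at a limit, so no step can be read between compound 2 and compound 3: the limit of > 27000 nM in this assay, at which 2 of the 3 values shown sit.

The compounds shown leave open how 1,2,3,4-tetrahydroisoquinolin-2-yl and phenyl(propyl)amino on a carbonyl carbon compare on this read-out.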